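A few compounds are considered here, and "the series" means these few. Any claim that something is new, unique, unknown or untested is made for them only; others in the source may bear on it.

Measured compounds:
compound 1 `CN1CCN(C[C@H]2CN(c3ccc(-n4cc(-c5ccccn5)cn4)c(F)c3)C(=O)O2)CC1` 2.2
compound 2 `COC(=O)CC1CCN(C[C@H]2CN(c3ccc(-n4cc(-c5ccccn5)cn4)c(F)c3)C(=O)O2)CC1` 1.78
compound 3 `CC(=O)OC[C@H]1CN(c2ccc(-n3cc(-c4ccccn4)cn3)c(F)c2)C(=O)O1` 2.09

In a physicochemical assay for lipophilicity, read by HPLC, measured as octanol-water partition (on this read-out lower numbers stand for lower lipophilicity and higher numbers for higher lipophilicity), compound 2 gives 1.78, the lowest of the three; compound 3 is a number 0.31 log units higher from compound 2 to compound 3 (beyond the scatter) and compound 1 stands higher still, a number 0.42 log units lower from compound 1 to compound 2 (beyond the scatter). Compound 4 `CCC(=O)NC[C@H]1CN(c2ccc(-n3cc(-c4ccccn4)cn3)c(F)c2)C(=O)O1` keeps the shared core and differs from compound 2 in one place: propanoylamino in place of 4-((methoxycarbonyl)methyl)piperidin-1-yl on a saturated chain carbon bound to a saturated ring carbon. The step that bears most directly on it is a number 0.31 log units higher from compound 2 to compound 3 (beyond the scatter), where a small group replaced the same piperidinyl substituent; a number 0.11 log units lower from compound 1 to compound 3 (within the scatter) shows that small groups on this carbon sit close together. A small step in this assay, possibly within the scatter, is therefore expected, a number 0.08 log units lower from compound 2 to compound 4 (within the scatter). Compound 4 is estimated at 1.7, in the range 1.3 to 2.1.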

Compound 4, partition coefficient: 2.2
For compound 4 the middle estimate is 0.50 log units below the measured one, outside the stated range (above it).
By their numbers in this assay, from the lowest: compound 2; then compounds 3, 1 and 4 (each within the scatter of the next).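

In this assay, propanoylamino on this saturated chain carbon stands clear of 4-((methoxycarbonyl)methyl)piperidin-1-yl (a number 0.42 log units higher from compound 2 to compound 4 (beyond the scatter)), which leaves compound 2 alone apart from the other three. Against acetoxy the change reads a number 0.11 log units higher from compound 3 to compound 4 (within the scatter) and against 4-methylpiperazin-1-yl it reads no change at the digits printed from compound 1 to compound 4 (within the scatter), so these three groups cannot be told apart in this read-out. No measured evidence accounts for this result. Still open, as far as these compounds go, is whether a carboxylic acid, a primary amine or a longer acyl chain on this carbon would group with compound 2 or with compound 1, compound 3 and compound 4.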